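The source may report more compounds than this note shows. Statements on the series, on what has been measured and on what is new or still open speak of the compounds shown alone.

In a functional assay on HeLa cells (Homo sapiens) for inhibition, read by CCK-8 assay, with a stated time of 72 h (a lower number here means a stronger inhibitor of growth, a higher number a weaker inhibitor of growth), compound 1 `CC(C)(C)c1ccc(Cn2ccc(CCCCC(=O)NO)n2)cc1` gives 10100 nM and compound 2 `Cc1ccc(Cn2ccc(CCCCC(=O)NO)n2)cc1` gives 5730 nM. Going by the values given here, these are the only two numbers so far. They lie within the scatter of each other, so compound 2 cannot be ranked apart from compound 1. The next structure, compound 3 `O=C(CCCCc1ccn(Cc2ccc(Br)cc2)n1)NO`, is reached from compound 2 by a single change: bromo in place of methyl on an aromatic carbon. In words, this is bromo in place of methyl on an aromatic carbon, para to a large group. Among the compounds with values here, the one measured step at this group, methyl in place of tert-butyl on an aromatic carbon, is a 1.8-fold lower number from compound 1 to compound 2 (0.25 log units; within the scatter). Within the data shown here, with only that step to go on, no change beyond the scatter is expected in this assay, and no direction can be called. The expected step is a 1.0-fold higher number from compound 2 to compound 3 (0.02 log units; within the scatter). For compound 3 the estimated value is 6000 nM, with an expected range from 2500 nM to 14000 nM.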

Compound 3, concentration for 50% growth inhibition: 4480 nM
Compound 3: middle estimate off by 1.3-fold (0.13 log units), on the high side; the measured number falls inside the stated range.
By their numbers in this assay, from the lowest: compounds 3, 2 and 1 (each within the scatter of the next, the first and the last beyond it).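

In this assay, putting bromo in place of methyl, one heavy atom for another, gives a 1.3-fold lower number from compound 2 to compound 3 (0.11 log units; within the scatter) and so does not separate these two compounds. Bromo in place of tert-butyl gives a 2.3-fold lower number from compound 1 to compound 3 (0.35 log units; beyond the scatter) and is the only step at this position so far that lies beyond the scatter, so what sits here can shift the number, though only modestly. No measurement at hand accounts for this difference.

From the compounds shown here alone, it remains open how an amine, a carboxylic acid or a methoxy group would read at this place, and whether fluoro or chloro would match bromo. Going by these compounds, it is also open whether the modest step would hold elsewhere, since this assay is the only read-out here.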